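Taking the methyl groups off compound 3

This account rests on a few compounds, and the source may have more. Where it says the series, first, only, none or still open, it means among the compounds named here.

Compound 1 `Cc1ccc(N2CCN(C(=O)c3oc(C)nc3-c3ccccc3)CC2)cc1` returns only a limit in a functional assay on HL-60 cells (Homo sapiens) for inhibition, read by MTT assay, with a stated time of 72 h (on this read-out lower numbers stand for stronger inhibition and higher numbers for weaker inhibition), > 1000 nM. Compound 2 `Cc1ccc(N2CCN(C(=O)c3oc(C)nc3-c3ccccc3)CC2)c(C)c1` gives 101 nM. Compound 3 `Cc1nc(-c2ccccc2)c(C(=O)N2CCN(c3c(C)cccc3C)CC2)o1` gives 146 nM, and a 1.4-fold higher number from compound 2 to compound 3 (0.16 log units; within the scatter), so these two stand level. Compound 4 `Cc1nc(-c2ccccc2)c(C(=O)N2CCN(c3ccccc3)CC2)o1` has phenyl in place of 2,6-dimethylphenyl on an amine nitrogen in a ring. Among the compounds with values here, two measured steps bear on this change: an at least 9.9-fold lower number from compound 1 to compound 2 (0.99 log units; beyond the scatter) and an at least 6.8-fold lower number from compound 1 to compound 3 (0.83 log units; beyond the scatter). Both are open-ended, and both show numbers falling as methyl groups are gained, so losing them should raise the number by a step beyond the scatter. The expected change is a 6.2-fold higher number from compound 3 to compound 4 (0.79 log units; beyond the scatter). For compound 4 the estimated value is 900 nM, within an expected range of 300 nM to 3000 nM.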

Compound 4, half-maximal inhibitory concentration: 39.1 nM
For compound 4 the middle estimate is 23-fold (1.36 log units) above the measured one; measured number below the stated range.
By their numbers in this assay, from the lowest: compound 4; then compounds 2 and 3 (each within the scatter of the next). At a limit, above all of these: compound 1.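

In this assay the plain phenyl of compound 4 carries the lowest number shown, so no methyl group is needed here: a 3.7-fold lower number from compound 3 to compound 4 (0.57 log units; beyond the scatter) and a 2.6-fold lower number from compound 2 to compound 4 (0.41 log units; beyond the scatter). The largest change comes with a single methyl, an at least 25-fold lower number from compound 1 to compound 4 (1.40 log units; beyond the scatter), so adding methyl groups does not move the number in one direction across these compounds. That step is open-ended, as it rests on a limit: the limit of > 1000 nM in this assay, at which 1 of the 4 values shown sits.

As far as these compounds go, it remains open whether a methoxy group or a chlorine atom on the phenyl would follow compound 1 or compounds 2 and 3.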